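Masking the Phenol Oxygen in a Thiazolidinone Series

This account rests on a few compounds, and the source may have more. Where it says the series, first, only, none or still open, it means among the compounds named here.

Measured compounds:
Compound 1, `O=C1CSC(c2cccc(O)c2)N1CCN1CCCCC1`, gives 100% in an ADME assay on Vero cells (Chlorocebus sabaeus) for cytotoxicity, read by neutral red uptake, tested at 394 ug/mL; a lower number here means a stronger effect, a higher number a weaker effect of the compound at the concentration tested.
Compound 2, `O=C1CSC(c2ccc(O)cc2)N1CCN1CCCCC1`, gives 76% in this assay.
Compound 3, `Cc1ccc(C2SCC(=O)N2CCN2CCCCC2)cc1`, gives 51% in this assay.

Compound 1 stands highest of the three numbers, with compound 2 nearest and compound 3 furthest: the step of a number 24 percentage points lower from compound 1 to compound 2 (beyond the scatter) is modest, while the step of a number 49 percentage points lower from compound 1 to compound 3 (beyond the scatter) is large. The shared core is kept in every case; only the group on the saturated ring carbon varies.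

Compound 4, `COc1cccc(C2SCC(=O)N2CCN2CCCCC2)c1`, has not been measured. It differs from compound 1 by methyl in place of hydrogen on an oxygen on an aromatic ring; cut one bond further out, the change reads hydroxy to methoxy.

Among the measured compounds shown here, no measured step makes exactly this change. The closest guide is a number 25 percentage points lower from compound 2 to compound 3 (beyond the scatter), where methyl replaced hydroxy on an aromatic carbon and the number fell modestly; the large fall in a number 49 percentage points lower from compound 1 to compound 3 (beyond the scatter) also removed the hydroxy. Because of a number 25 percentage points lower from compound 2 to compound 3 (beyond the scatter), a modest drop from compound 1 is expected, giving a number 20 percentage points lower from compound 1 to compound 4 (beyond the scatter). Compound 4 is therefore estimated at 80%, within 60% to 100%.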

Compound 4, a percentage reported as activity, at one concentration (the size of the read-out at that concentration, not a potency): 57%
Beside the measured number, compound 4's estimate is 23 percentage points above it; the whole stated range lies above it.
By their numbers in this assay, from the lowest: compounds 3 and 4 (each within the scatter of the next); then compound 2; then compound 1.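

Adding a single methyl to the hydroxy oxygen of compound 1 is enough to produce a large change in this assay, with a number 43 percentage points lower from compound 1 to compound 4 (beyond the scatter). The oxygen stays on the aromatic ring in compound 4, so at this position keeping that atom does not keep the number of compound 1; replacing only the hydrogen on it already matters. Nothing available here explains why this small change has so large an effect.

Still open, from the compounds shown here alone, is whether an ethyl group or a longer chain on the same oxygen would move the number further, or whether an amine in place of the hydroxy would behave like the methoxy. Going by these compounds, it also remains unknown whether adding methyl to the hydroxy oxygen of compound 2 would produce a step of similar size.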